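Side-chain variation at a shared core

This account rests on a few compounds, and the source may have more. Where it says the series, first, only, none or still open, it means among the compounds named here.

Measured so far in a functional assay on K562 cells (Homo sapiens) for inhibition; on this read-out higher numbers stand for weaker inhibition and lower numbers for stronger inhibition:
compound 1 `CCCCc1cc(C)oc(=O)c1` — > 50000 nM
compound 2 `CCCCC#Cc1cc(C)oc(=O)c1` — 15500 nM
compound 3 `CCc1cc(C)oc(=O)c1` — > 50000 nM

Compound 3 stands at a limit of this assay, > 50000 nM, not at a number. Compound 1 likewise stands at a limit, > 50000 nM. Among the measured compounds shown here, the only counted step, a step that the two limits leave unreadable from compound 1 to compound 3, is unreadable because of the limit of > 50000 nM in this assay, at which 2 of the 3 values shown sit. For the measured compounds named here, compound 2 alone gives a number, 15500 nM; no step to it is counted, so its values are simply noted.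

Compound 4 `CCOCCc1cc(C)oc(=O)c1` differs from compound 3 by ethoxy in place of hydrogen on a saturated chain carbon, two bonds along the chain from an aromatic carbon. Going by the values given here, no measured step bears on ethoxy entering the chain, and nothing here places the new compound away from the limit. The step from compound 3 to compound 4 is expected at a step that the limit leaves unreadable from compound 3 to compound 4, unreadable in size. Compound 4 is expected at 60000 nM, between 20000 nM and 200000 nM, most likely reported again as a limit.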

Compound 4, half-maximal inhibitory concentration: > 50000 nM
Compound 4: a limit, no number (the forecaster's own chance of this, stated with the estimate: 70%); the middle value does not contradict the limit.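

The steps from compound 1 and compound 3 to compound 4 cannot be read, because all three compounds stand at the same limit: the limit of > 50000 nM in this assay, at which 3 of the 4 values shown sit.

On these data alone, how far these three compounds actually differ in inhibition stays open.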